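Taking the Bromine Off Compound 1

The compounds below may be only part of what the source reports. "The series", "measured", "known", "first", "only" and "open" are said of these compounds alone.

Compound 1 `Cc1ccc2oc(-c3cccc(Br)c3)cc2c1` has been tested in an assay on cells for inhibition of Amine oxidase [flavin-containing] A (Homo sapiens), read by fluorescence and Amplex Red, with a stated time of 15 min; a higher number here means a weaker inhibitor, a lower number a stronger inhibitor. In this assay compound 1 gives only a limit, > 100000 nM, and not a number. Compound 2 `Brc1ccc(-c2cc3ccccc3o2)cc1` likewise gives a limit of > 100000 nM in this assay. Compound 3 `Cc1cccc2cc(-c3cccc(Br)c3)oc12` also gives a limit of > 100000 nM in this assay. Compound 1 therefore stands at the limit of > 100000 nM in this assay, at which 3 of the 3 values shown sit, together with both other compounds. Compound 4 `Cc1ccc2oc(-c3ccccc3)cc2c1` differs from compound 1 by hydrogen in place of bromo on an aromatic carbon. Within the data shown here, no measured pair shows what this change does. Among the measured compounds shown here, because every value so far sits at the limit of > 100000 nM in this assay, at which 3 of the 3 values shown sit, no step beyond the scatter is expected in this assay in either direction. The expected step that the limit leaves unreadable from compound 1 to compound 4 is essentially none. Compound 4 is estimated at 150000 nM, within 30000 nM to 1000000 nM.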

Compound 4, half-maximal inhibitory concentration: > 100000 nM
Compound 4 ended at the assay's limit; the forecaster's own chance of this, stated with the estimate: 80%; the middle value lies beyond the limit too.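

Compound 1 and compound 4 each give only a limit in this assay, and no step can be read for hydrogen in place of bromo. Which change to the shared core would give a measurable value stays open.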